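Carboxy in Place of Hydroxy: An Untested Step

A few compounds are considered here, and "the series" means these few. Any claim that something is new, unique, unknown or untested is made for them only; others in the source may bear on it.

Compound 1 `Cc1c(C(=O)Nc2c(F)cc(-c3cccc(F)c3)cc2F)nc2ccc(F)cc2c1O`: 15.3%
Compound 2 `CCOc1ccc2nc(C(=O)Nc3c(F)cc(-c4cccc(F)c4)cc3F)c(C)c(O)c2c1`: 1.03%
Compound 3 `Cc1c(C(=O)Nc2c(F)cc(-c3cccc(F)c3)cc2F)nc2ccc(OC(F)(F)F)cc2c1O`: 17.2%

In a functional assay on Hep 3B2 cells (Homo sapiens) for antiproliferative activity, read by MTT assay, with a stated time of 24 h, tested at 1.23 ug/mL (on this read-out higher numbers stand for a stronger effect at the one concentration tested and lower numbers for a weaker effect), compound 1 stands second highest of the three numbers. Its nearest neighbour is reached by a number 1.9 percentage points higher from compound 1 to compound 3 (within the scatter), a step within the scatter; its furthest by a number 14.3 percentage points lower from compound 1 to compound 2 (beyond the scatter), a step beyond it. The remaining step is a number 16.2 percentage points higher from compound 2 to compound 3 (beyond the scatter). Compound 4 `Cc1c(C(=O)Nc2c(F)cc(-c3cccc(F)c3)cc2F)nc2ccc(F)cc2c1C(=O)O` differs from compound 1 by carboxy in place of hydroxy on an aromatic carbon. Among the measured compounds shown here, no measured step touches this change: all three measured steps exchange the group on a different aromatic carbon and leave the hydroxy untouched, so the data give no direct guide. With all three measured numbers low and close together, compound 4 is expected to give 12% (from 0% to 30%). That estimate means an expected step of a number 3.3 percentage points lower from compound 1 to compound 4 (within the scatter), not beyond the scatter.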

Compound 4, a percentage reported as inhibition, at one concentration (the size of the read-out at that concentration, not a potency): 2.45%
Compound 4: the middle estimate sits 9.6 percentage points above what was measured; the range from low to high includes it.
By their numbers in this assay, from the lowest: compounds 2 and 4 (each within the scatter of the next); then compounds 1 and 3 (each within the scatter of the next).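

In this assay, among the compounds shown here, the exchange of hydroxy for carboxy, opposite the ring nitrogen, gives a number 12.9 percentage points lower from compound 1 to compound 4 (beyond the scatter), so this position, which no earlier step touched, also moves the read-out beyond the scatter. The earlier steps shown here showed this only for the group on a different aromatic carbon. Nothing available explains the drop with carboxy. The compounds shown leave open how an amine or a methoxy group would fare at this position, and whether carboxy would lower the number likewise in compound 2 and compound 3.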